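This account rests on a few compounds, and the source may have more. Where it says the series, first, only, none or still open, it means among the compounds named here.

Compound 1 `c1ccc(COc2cccc(OCCCc3nnn[nH]3)c2)cc1`: in a functional assay (Cavia porcellus) for inhibition of cysteinyl leukotriene receptor (Homo sapiens), tested at 10 uM (on this read-out lower numbers stand for less inhibition and higher numbers for more inhibition at the one concentration tested (going by the name of the read-out)), compound 1 gives 9%.
Compound 2 `c1ccc(COc2cccc(OCCCc3nnn[nH]3)c2)nc1`: in this assay compound 2 gives 18%.

Compound 2 carries the larger of the two numbers, but only nominally: the step of a number 9 percentage points higher from compound 1 to compound 2 (within the scatter) lies within the scatter, so compound 1 and compound 2 are not separated by the measurements at hand.

Compound 3 `c1ccc(Oc2cccc(COc3cccc(OCCCc4nnn[nH]4)c3)n2)cc1` is the next member and has not yet been measured in this assay. It differs from compound 2 in one place: phenoxy in place of hydrogen on an aromatic carbon. Among the compounds with values here, the only measured step, from compound 1 to compound 2, changes a different part of the molecule, pyridin-2-yl in place of phenyl on the saturated chain carbon bound to the aromatic oxygen, and its size, a number 9 percentage points higher from compound 1 to compound 2 (within the scatter), is within the scatter. Within the data shown here, no measured step touches an aromatic carbon of the ring with one nitrogen, so nothing in the data points to a step beyond the scatter in either direction.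

The step from compound 2 to compound 3 is therefore expected to be small, a number 2 percentage points higher from compound 2 to compound 3 (within the scatter). For compound 3 the estimate in this assay is 20%, expected to fall between 3% and 42%.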

Compound 3, a percentage reported as inhibition, at one concentration (the size of the read-out at that concentration, not a potency): 9%
Estimate against measurement, compound 3: 11 percentage points above; measured number inside the range.
By their numbers in this assay, from the lowest: compounds 1, 3 and 2 (each within the scatter of the next).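

Phenoxy on the aromatic carbon next to the ring nitrogen, meta to a large group, is the only change at this position among the compounds shown, and in this assay the step reads a number 9 percentage points lower from compound 2 to compound 3 (within the scatter) and so does not separate the pair. A substituent of this size, with 7 heavy atoms and a six-membered aromatic ring of carbon only, is therefore accommodated at this carbon with no change in the read-out that the measurements can resolve, which the earlier pair, altered elsewhere in the molecule, could not show. The data on hand offer no explanation for this result.

Still open, from the compounds shown here alone, is whether a different group on this same carbon, such as an amine or a methoxy group, or a carboxylic acid on the added phenoxy ring, would give a step beyond the scatter in this assay in either direction. Also open is whether a longer chain on the shared core would do so, and a reading at one concentration gives no potency for any of these compounds.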